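Chloro to Bromo: What to Expect for Compound 4

The source may report more compounds than this note shows. Statements on the series, on what has been measured and on what is new or still open speak of the compounds shown alone.

Measured so far:
compound 1 `Cc1ccc(OCC(=O)NNC(=O)c2cc3ccccc3oc2=O)c(C(=O)c2cccc(Cl)c2)c1`: 64900 nM
compound 2 `Cc1ccc(OCC(=O)NNC(=O)c2cc3ccccc3oc2=O)c(C(=O)c2ccccc2Br)c1`: 8000 nM
compound 3 `Cc1ccc(OCC(=O)NNC(=O)c2cc3ccccc3oc2=O)c(C(=O)c2ccccc2)c1`: 78400 nM

In a functional assay on Ehrlich cells (Mus musculus) for cytotoxicity, read by MTT assay, with a stated time of 48 h (a higher number here means a weaker inhibitor, a lower number a stronger inhibitor), compound 1 gives the second highest of the three numbers; its nearest neighbour is compound 3, a 1.2-fold higher number from compound 1 to compound 3 (0.08 log units; within the scatter), while compound 2 is furthest, an 8.1-fold lower number from compound 1 to compound 2 (0.91 log units; beyond the scatter). Compound 4 `Cc1ccc(OCC(=O)NNC(=O)c2cc3ccccc3oc2=O)c(C(=O)c2cccc(Br)c2)c1` differs from compound 1 by bromo in place of chloro on an aromatic carbon. Among the compounds with values here, two measured steps bear on this. a 1.2-fold higher number from compound 1 to compound 3 (0.08 log units; within the scatter) shows that removing the chloro changes little. a 9.8-fold higher number from compound 2 to compound 3 (0.99 log units; beyond the scatter) shows that the bromo of the 2-bromophenyl group matters, but that bromo sits at a different place. A halogen swap at the same place is therefore expected to give a 1.4-fold lower number from compound 1 to compound 4 (0.16 log units; within the scatter), within the scatter. Compound 4 is expected to give 45000 nM, with a range from 15000 nM to 130000 nM.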

Compound 4, half-maximal inhibitory concentration: 66400 nM
Compound 4: middle estimate off by 1.5-fold (0.17 log units), on the low side, within the range that was stated.
By their numbers in this assay, from the lowest: compound 2; then compounds 1, 4 and 3 (each within the scatter of the next).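

At this place the halogen hardly counts: a 1.0-fold higher number from compound 1 to compound 4 (0.01 log units; within the scatter) and a 1.2-fold lower number from compound 3 to compound 4 (0.07 log units; within the scatter) in this assay show that neither bromo for chloro nor bromo for hydrogen moves the number beyond the scatter. Moving the bromo does matter: an 8.3-fold higher number from compound 2 to compound 4 (0.92 log units; beyond the scatter) sets the 3-bromophenyl group apart from the 2-bromophenyl group, so the earlier bromo effect belongs to that other place and not to bromo as such. Nothing shown gives a reason for this difference.

On these data alone, it stays open whether an amine or a carboxylic acid at this place would shift the number, and whether chloro would match bromo where compound 2 carries it.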